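The source may hold more compounds than are shown below. What is called first, only, known or untested is meant among the compounds shown, and "the series" means these compounds.

Of the compounds shown here, two sharing one core have so far been tested in a functional assay on the whole organism for inhibition, with Rattus norvegicus as the target, read by paw edema, in the formalin test, with a stated time of 0.5 h, at a dose of 100 mg/kg by the intraperitoneal route; a lower number here means less inhibition, a higher number more inhibition at the dose given (going by the name of the read-out). Compound 1, `O=c1cc(CNc2nc(-c3cc4cc(Br)cc(Br)c4oc3=O)cs2)c2cc(Cl)ccc2[nH]1`, gives 6.75% in that assay. Compound 2, `Cc1cccc2c(CNc3nc(-c4cc5cc(Br)ccc5oc4=O)cs3)cc(=O)[nH]c12`, gives 3.12%; this is the lower of the two numbers shown, but the gap to compound 1 lies within the usual scatter, so the two compounds cannot be set apart on these readings. Compound 3, `Cc1cccc2c(CNc3nc(-c4cc5cc(Br)cc(Br)c5oc4=O)cs3)cc(=O)[nH]c12`, has not yet been measured. It differs from compound 2 in one place: bromo in place of hydrogen on an aromatic carbon. Within the data shown here, no measured pair shows this change on its own, so its effect is not known from the data. Among the measured compounds shown here, nothing among the measured compounds points to a rise, since compound 1 also gives a low number, 6.75%. The step of a number 1.9 percentage points higher from compound 2 to compound 3 (within the scatter) is therefore expected to be small, with no direction beyond the scatter. Compound 3 is estimated at 5%, with a range from 0% to 15%.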

Compound 3, a percentage reported as inhibition, in the whole organism at one dose (the size of the read-out at that dose, not a potency): 3.65%
Estimate against measurement, compound 3: 1.4 percentage points above; measured number inside the range.
By their numbers in this assay, from the lowest: compounds 2, 3 and 1 (each within the scatter of the next).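

In this assay, bromo in place of hydrogen on this aromatic carbon, ortho to a fused ring, gives a number 0.5 percentage points higher from compound 2 to compound 3 (within the scatter). Among these compounds, this pair is the first to show the change on its own, and at this single dose the added bromine atom does not set the two compounds apart, so this position shows no measurable response to bromo. No supporting data bear on this reading.

Going by these compounds, it remains open whether a different group on this carbon, such as an amine, a carboxylic acid or a longer alkyl chain, would give a number that differs beyond the scatter. On these data alone, it is also open whether bromo would leave the reading equally unchanged at another dose or another time point.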